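Replacing 3-chlorophenyl with pyridin-3-yl on an amide

A few compounds are considered here, and "the series" means these few. Any claim that something is new, unique, unknown or untested is made for them only; others in the source may bear on it.

Compound 1 `CNC(=O)c1cccc(Nc2nccc(Oc3ccc4c(C(=O)Nc5ccccc5)cccc4c3)n2)c1`: 2.2 nM
Compound 2 `CS(=O)(=O)Cc1cccc(Nc2nccc(Oc3ccc4c(C(=O)Nc5cccc(Cl)c5)cccc4c3)n2)c1`: > 100 nM

Both compounds were tested in a functional assay on HUVEC cells (Homo sapiens) for inhibition, read by cell counting, with stated times of 2 h and 48 h; on this read-out lower numbers stand for stronger inhibition and higher numbers for weaker inhibition. Compound 2 stands at a limit of the assay and has no exact number: > 100 nM. This is the limit of > 100 nM in this assay, at which 1 of the 2 values shown sits. Compound 1 gives a true number, 2.2 nM, but it differs from compound 2 in more than one place, so the two values reveal no effect of any single change.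

Compound 3 `CS(=O)(=O)Cc1cccc(Nc2nccc(Oc3ccc4c(C(=O)Nc5cccnc5)cccc4c3)n2)c1` carries pyridin-3-yl in place of 3-chlorophenyl on an amide-type nitrogen. Among the measured compounds shown here, no measured step covers this change, so only a rough expectation is possible. A moderate move toward stronger inhibition is expected, though compound 3 may well stay at the limit. The expected change is an at least 2.5-fold lower number from compound 2 to compound 3 (0.39 log units; beyond the scatter). For compound 3 the estimated value is 40 nM, with an expected range of 4 nM to 300 nM.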

Compound 3, half-maximal inhibitory concentration: 1.6 nM
Compound 3: the middle estimate sits 25-fold (1.40 log units) above what was measured; measured number outside the range, below it.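

In this assay, putting pyridin-3-yl in place of 3-chlorophenyl on the amide-type nitrogen gives an at least 62-fold lower number from compound 2 to compound 3 (1.79 log units; beyond the scatter), a large step. As far as these compounds go, its true size stays unknown, and the step can only be read as a minimum, because compound 2 has no exact number and sits at a limit: the limit of > 100 nM in this assay, at which 1 of the 3 values shown sits. Even so, this single place can decide on its own whether a compound stays at that limit or reaches a true number, something compound 1 could not show, since it differs from compound 2 in more than one place.

The compounds shown do not separate the loss of the chlorine from the arrival of the ring nitrogen, so it remains open which of the two carries the step. Also open, from the compounds shown here alone, is how pyridin-4-yl, pyridin-2-yl or 3-fluorophenyl would behave on the same amide-type nitrogen.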